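This account rests on a few compounds, and the source may have more. Where it says the series, first, only, none or still open, it means among the compounds named here.

Working notes on the series. Among the compounds with values here, in an assay on isolated protein for inhibition of protein kinase C delta type (Homo sapiens), read by TR-FRET, with a stated time of 2 h (a lower number here means a stronger inhibitor, a higher number a weaker inhibitor), compound 1 `N#Cc1cnc(NCc2cnccc2C(F)(F)F)cc1NC[C@H]1CC[C@@H](O)CC1` gives 500 nM, the lowest of the two numbers known so far. Within the data shown here, compound 2 `CC1(C)[C@H](O)C[C@H]1Nc1nc(NCc2cnccc2C(F)(F)F)ncc1C#N`, which carries a different core and a different ring on the amine, gives 4500 nM in this assay, a gap to compound 1 well beyond the usual scatter; no single-point step connects the two, so the pair only shows that compound 1 is the stronger of the two.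

Compound 3 `CC1(C)[C@H](Nc2cc(NCc3cnccc3C(F)(F)F)ncc2C#N)C[C@H]1C(N)=O` keeps the core of compound 1 and differs in one place: 3-carbamoyl-2,2-dimethylcyclobutyl in place of (4-hydroxycyclohexyl)methyl on a nitrogen on an aromatic ring. The ring shrinks, the linking chain is dropped, and the hydroxyl gives way to a carbamoyl group. Among the measured compounds shown here, no measured step of this kind exists in the set, so the direction is uncertain; a modest loss is expected, roughly at the edge of the scatter, in the step of a 1.8-fold higher number from compound 1 to compound 3 (0.26 log units; within the scatter). On that basis compound 3 is estimated at 900 nM, within a range from 200 nM to 4000 nM.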

Compound 3, half-maximal inhibitory concentration: 900 nM
Compound 3: middle estimate and measured number agree at the digits printed, within the range that was stated.
By their numbers in this assay, from the lowest: compounds 1 and 3 (each within the scatter of the next); then compound 2.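

In this assay, within the data shown here, this is the first step at the position on a nitrogen on an aromatic ring: 3-carbamoyl-2,2-dimethylcyclobutyl in place of (4-hydroxycyclohexyl)methyl gives a 1.8-fold higher number from compound 1 to compound 3 (0.26 log units; within the scatter) on the core of compound 1. The position therefore accepts a substantial exchange of the group, with a four-membered ring carrying a carbamoyl group and a six-membered ring carrying a hydroxyl group giving numbers that this assay does not separate. Nothing measured on these compounds accounts for this outcome.

Among these compounds, the single step changes the ring, the carbamoyl or hydroxyl group and the linking chain together, so their separate contributions remain open. Also open, from the compounds shown here alone, is how a carboxylic acid or an amine in place of the carbamoyl group would read at this position, or a longer chain between the nitrogen and the ring.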